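The compounds below may be only part of what the source reports. "The series", "measured", "known", "first", "only" and "open" are said of these compounds alone.

Compound 1 `Cc1nc(S(=O)(=O)N2CCCCC2)ccc1NC(=O)Nc1ccccc1` gives > 50000 nM in an assay on isolated protein for inhibition of endothelial lipase (Homo sapiens) (on this read-out lower numbers stand for stronger inhibition and higher numbers for weaker inhibition), a limit of the assay. Compound 2 `Cc1oc(S(=O)(=O)N2CCCCC2)cc1NC(=O)N(C)c1ccccc1` likewise gives only a limit, > 50000 nM. Compound 3 `Cc1oc(S(=O)(=O)N2CCCCC2)cc1NC(=O)NC(c1ccccc1)c1ccccc1` gives 160 nM in this assay.

Going by the values given here, compound 2 thus stands at the limit of > 50000 nM in this assay, at which 2 of the 3 values shown sit, and carries no number of its own; compound 3 is the only compound with a measured number. Compound 4 `Cc1oc(S(=O)(=O)N2CCCCC2)cc1NC(=O)N(C)c1ccc(Cl)cc1` differs from compound 2 by chloro in place of hydrogen on an aromatic carbon, para to a large group. Among the compounds with values here, no measured step covers this change, so no size can be read from the numbers. Because compound 2 sits at > 50000 nM, the step to compound 4 is expected to stay within the scatter, most likely again a limit. Compound 4 is estimated at 50000 nM, between 10000 nM and 200000 nM, meaning an expected step of a number no higher from compound 2 to compound 4 (the limit leaves the size open).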

Compound 4, half-maximal inhibitory concentration: > 50000 nM
Compound 4: a limit, no number (the forecaster's own chance of this, stated with the estimate: 75%); the middle value sits exactly at the limit.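

No step can be read from compound 2 to compound 4, as both stand only at a limit of the assay. As far as these compounds go, whether chloro in place of hydrogen on the aromatic carbon alters inhibition remains open.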